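The source may report more compounds than this note shows. Statements on the series, on what has been measured and on what is new or still open speak of the compounds shown alone.

Compound 1 `COc1ccc(C2=Nc3c(C(C)(C)C)nn(CCCO)c3C(=O)NC2)cc1-c1ccc(C(=O)O)cc1` was tested in an ADME assay on microsomes from liver (Homo sapiens) for metabolic stability (on this read-out higher numbers stand for a longer-lived compound and lower numbers for a shorter-lived compound), where compound 1 gives 2 h. Two close relatives help place it. Compound 2 `COc1ccc(-c2cc(C3=Nc4c(C(C)(C)C)nn(CCCO)c4C(=O)NC3)ccc2OC)cn1` gives 2 h in this assay, and compound 3 `COc1ccc(OC)c(-c2cc(C3=Nc4c(C(C)(C)C)nn(CCCO)c4C(=O)NC3)ccc2OC)c1` gives 1.02 h. Compound 1 thus sits level with compound 2, the step being no change at the digits printed from compound 1 to compound 2 (within the scatter), while against compound 3 the step is a 2.0-fold lower number from compound 1 to compound 3 (0.29 log units; within the scatter); neither of these steps reaches beyond what repeated measurements normally scatter, so the three compounds cannot be told apart on this read-out.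

Compound 4 `COc1ccc(C2=Nc3c(C(C)(C)C)nn(CCCO)c3C(=O)NC2)cc1-c1ccc(F)cc1F` is the next compound in the series. It differs from compound 1 in a single place: 2,4-difluorophenyl in place of 4-carboxyphenyl on an aromatic carbon. The change sits at the same position that was varied between compound 1 and compound 2 and between compound 1 and compound 3, so those two steps bear on it directly. For the measured compounds named here, both were small and within the scatter, and nothing among the measured compounds points to a larger effect of swapping the group at this position. The step from compound 1 to compound 4 is therefore expected to be a 1.3-fold lower number from compound 1 to compound 4 (0.10 log units; within the scatter), that is, no change beyond the scatter. Compound 4 is estimated to give 1.6 h in this assay, with a range from 0.7 h to 3.5 h.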

Compound 4, half-life: 2 h
Compound 4: the middle estimate sits 1.3-fold (0.10 log units) below what was measured, and the stated range covers the measured number.
By their numbers in this assay, from the lowest: compounds 3, 1, 2 and 4 (each within the scatter of the next).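

In this assay the 2,4-difluorophenyl group joins the three groups already seen at this position, and the new readings give no change at the digits printed from compound 1 to compound 4 (within the scatter) and no change at the digits printed from compound 2 to compound 4 (within the scatter) as well as a 2.0-fold higher number from compound 3 to compound 4 (0.29 log units; within the scatter) and so leave all four compounds within the scatter of one another. What is new is the kind of group: 4-carboxyphenyl carries a hydrogen-bond donor and a hydrogen-bond acceptor while 2,4-difluorophenyl carries neither, and two fluorine atoms stand where that group had two oxygen atoms, yet this exchange on an aromatic carbon ortho to a methoxy group does not separate the compounds on this read-out. Why the half-life stays so flat cannot be said from anything given here.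

In this assay, on these data alone, all four groups at this position are built on a six-membered aromatic ring, so the outcome for a different sort of group there, such as an amine or a simple alkyl chain, remains open. All four compounds also share the rest of the core of compound 1, which leaves open whether these groups would still behave alike on a changed core.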